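Piperidine amide to benzylamide in a dienamide series

The source may report more compounds than this note shows. Statements on the series, on what has been measured and on what is new or still open speak of the compounds shown alone.

Three dienamides sharing the core of compound 1 `COc1ccc(C[C@@H](O)/C=C/C=C/C(=O)N2CCCCC2)cc1OC` have been run in a functional assay on MCF7 cells (Homo sapiens) for antiproliferative activity, read by sulforhodamine B assay, with a stated time of 48 h; a lower number here means a stronger inhibitor, a higher number a weaker inhibitor. Compound 1 gives 39500 nM, the highest number of the three. Compound 2 `COc1ccc(C[C@@H](O)/C=C/C=C/C(=O)N2CCN(C(c3ccccc3)c3ccccc3)CC2)cc1OC`, which carries a benzhydrylpiperazine, gives 12500 nM in this assay, and compound 3 `COc1ccc(C[C@@H](O)/C=C/C=C/C(=O)NCc2cc(OC)c(OC)c(OC)c2)cc1OC`, a trimethoxybenzylamide, gives 15300 nM. Both gaps from compound 1 lie beyond the usual scatter, so compound 1 is the weakest inhibitor of the measured set, while compound 2 and compound 3 sit within scatter of each other and cannot be ordered.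

Compound 4 `COc1ccc(C[C@@H](O)/C=C/C=C/C(=O)NCc2ccccc2)cc1OC` is not yet measured. It differs from compound 1 in one place: benzylamino in place of piperidin-1-yl on a carbonyl carbon. Among the measured compounds shown here, no measured pair in this set isolates that change, so the expectation rests on the open secondary amides as a group. Compound 3 shows that a benzylamino-type amide on this carbonyl can give a lower number than compound 1; compound 4 lacks the three methoxy groups of compound 3, so a smaller gain is expected. The step of a 1.8-fold lower number from compound 1 to compound 4 (0.25 log units; within the scatter) is expected to be a modest drop, close to the edge of scatter. Compound 4 is therefore expected to give about 22000 nM in this assay, within a range of 9000 nM to 50000 nM.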

Compound 4, half-maximal inhibitory concentration: 33600 nM
Estimate against measurement, compound 4: 1.5-fold (0.18 log units) below; the measured number falls inside the stated range.
By their numbers in this assay, from the lowest: compounds 2 and 3 (each within the scatter of the next); then compounds 4 and 1 (each within the scatter of the next).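

In this assay, benzylamino in place of piperidin-1-yl on a carbonyl carbon gives a 1.2-fold lower number from compound 1 to compound 4 (0.07 log units; within the scatter), so this change has no effect that can be told from scatter. Among the compounds shown here, the piece entering brings an aromatic ring and a hydrogen-bond donor, yet together they leave the number unresolved from that of the piperidine amide, which the earlier compounds could not show because no measured pair isolated this change. The data at hand offer no measurement that could explain this result.

Still open, as far as these compounds go, is whether the aromatic ring and the amide hydrogen each have no effect here or whether two separate effects offset each other, and N-methylbenzylamino on this carbonyl carbon would keep the ring while removing that hydrogen. Also open, from the compounds shown here alone, is how the number responds to phenethylamino, with its longer chain to the aromatic ring, or to a single methoxy group or chlorine on the benzylamino ring of compound 4.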